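This account rests on a few compounds, and the source may have more. Where it says the series, first, only, none or still open, it means among the compounds named here.

Of the compounds shown here, three built on one shared core have been tested in a functional assay on HCT-116 cells (Homo sapiens) for cytotoxicity, read by WST assay, with a stated time of 72 h; on this read-out higher numbers stand for weaker inhibition and lower numbers for stronger inhibition. Compound 3 `COc1cc2c(Nc3nc4ccc(C(=O)Nc5c(C)cccc5Cl)cc4s3)ncnc2cc1OCCCN1CCC(C)CC1` gives 9100 nM there. Compound 1 `COc1cc2c(Nc3nc4ccc(C(=O)Nc5c(C)cc(C)cc5C)cc4s3)ncnc2cc1OCCCN1CCC(C)CC1` differs from it by one change, (2,4,6-trimethylphenyl in place of 2-chloro-6-methylphenyl on an amide-type nitrogen), and gives 6900 nM; the step of a 1.3-fold lower number from compound 3 to compound 1 (0.12 log units; within the scatter). Compound 2 `COc1cc2c(Nc3nc4ccc(C(=O)Nc5c(C)cccc5Cl)cc4s3)ncnc2cc1OCCCN1CCCCC1` differs from compound 3 at the other place, (hydrogen in place of methyl on a saturated ring carbon). In this assay compound 2 gives 23400 nM, the highest number of the three; the step of a 2.6-fold lower number from compound 2 to compound 3 (0.41 log units; beyond the scatter).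

Compound 4 `COc1cc2c(Nc3nc4ccc(C(=O)Nc5c(C)cc(C)cc5C)cc4s3)ncnc2cc1OCCCN1CCCCC1` has not yet been measured. It differs from compound 2 by 2,4,6-trimethylphenyl in place of 2-chloro-6-methylphenyl on an amide-type nitrogen, the same change, at the same place, as from compound 3 to compound 1, so this change occurs on two pairs. The expected step for compound 4 is a 1.2-fold lower number from compound 2 to compound 4 (0.09 log units; within the scatter), estimated to be small. This rests on the earlier step of a 1.3-fold lower number from compound 3 to compound 1 (0.12 log units; within the scatter). Compound 4 is therefore expected to give about 19000 nM, somewhere between 8000 nM and 45000 nM.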

Compound 4, half-maximal inhibitory concentration: 16900 nM
Beside the measured number, compound 4's estimate is 1.1-fold (0.05 log units) above it; measured number inside the range.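

In this assay, putting 2,4,6-trimethylphenyl in place of 2-chloro-6-methylphenyl on the amide-type nitrogen gives a 1.4-fold lower number from compound 2 to compound 4 (0.14 log units; within the scatter), and this step carries over from one core to the other: the same change on two cores in this assay, a 1.3-fold lower number (0.12 log units; within the scatter) from compound 3 to compound 1 and a 1.4-fold lower number (0.14 log units; within the scatter) from compound 2 to compound 4, 1.0-fold (0.02 log units) apart, within the scatter of two such steps

The other change, hydrogen in place of methyl on a saturated ring carbon, gives a 2.4-fold higher number from compound 1 to compound 4 (0.39 log units; beyond the scatter), and it too carries over when read in the opposite direction: the same change on two cores in this assay, a 2.6-fold lower number (0.41 log units; beyond the scatter) from compound 2 to compound 3 and a 2.4-fold lower number (0.39 log units; beyond the scatter) from compound 4 to compound 1, 1.0-fold (0.02 log units) apart, within the scatter of two such steps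

This agreement rests on just these four compounds, so it shows neither that the changes would carry over to other cores nor why they behave this way, and the aryl step itself stays within the scatter.

Still open, as far as these compounds go, is whether the steps would hold with a dimethylamino group in place of the saturated ring, or with a methoxy group in place of the chlorine.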